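The compounds below may be only part of what the source reports. "The series", "measured", "known", "first", "only" and "open" are said of these compounds alone.

Three measured compounds share one core and differ only in the group on the amide-type nitrogen. In a functional assay on PC-3 cells (Homo sapiens) for antiproliferative activity, read by MTT assay, with a stated time of 24 h (on this read-out lower numbers stand for stronger inhibition and higher numbers for weaker inhibition), compound 2 `CCn1c(C(=O)N[C@H](C)CO)ccc1C(CC)(CC)c1ccc(OCS(=O)(=O)c2ccccc2)c(C)c1` gives 7790 nM. Compound 1 `CCn1c(C(=O)NCCO)ccc1C(CC)(CC)c1ccc(OCS(=O)(=O)c2ccccc2)c(C)c1` gives 17700 nM in this assay, and compound 3 `CCn1c(C(=O)N[C@@H](C)C(=O)O)ccc1C(CC)(CC)c1ccc(OCS(=O)(=O)c2ccccc2)c(C)c1` gives 16800 nM. The change hydrogen in place of methyl on a saturated chain carbon bound to an amide-type nitrogen and a saturated chain carbon brought a 2.3-fold higher number from compound 2 to compound 1 (0.36 log units; beyond the scatter); the change 1-carboxyethyl in place of 1-(hydroxymethyl)ethyl on an amide-type nitrogen brought a 2.2-fold higher number from compound 2 to compound 3 (0.33 log units; beyond the scatter); and a 1.1-fold lower number from compound 1 to compound 3 (0.02 log units; within the scatter) separates the remaining pair.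

Compound 4 `CCn1c(C(=O)NCC(=O)O)ccc1C(CC)(CC)c1ccc(OCS(=O)(=O)c2ccccc2)c(C)c1` differs from compound 3 by hydrogen in place of methyl on a saturated chain carbon bound to an amide-type nitrogen and a carbonyl carbon. This is the same kind of change as that from compound 2 to compound 1, but not the same: there the carbon was bound to an amide-type nitrogen and a saturated chain carbon, here to an amide-type nitrogen and a carbonyl carbon. Because a 2.3-fold higher number from compound 2 to compound 1 (0.36 log units; beyond the scatter) was a modest weakening, a similar step is expected, a 1.7-fold higher number from compound 3 to compound 4 (0.22 log units; within the scatter). Compound 4 is estimated at 28000 nM, expected between 12000 nM and 65000 nM.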

Compound 4, half-maximal inhibitory concentration: 30100 nM
Beside the measured number, compound 4's estimate is 1.1-fold (0.03 log units) below it; the range from low to high includes it.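

Taking away the methyl pointed the same way on both cores in this assay, and the two steps agree in size, so the change carried over between this one pair of cores: the same change on two cores in this assay, a 2.3-fold higher number (0.36 log units; beyond the scatter) from compound 2 to compound 1 and a 1.8-fold higher number (0.25 log units; within the scatter) from compound 3 to compound 4, 1.3-fold (0.10 log units) apart, within the scatter of two such steps Alone, though, a 1.8-fold higher number from compound 3 to compound 4 (0.25 log units; within the scatter) is no firm change, and neither is a 1.7-fold higher number from compound 1 to compound 4 (0.23 log units; within the scatter), while carboxymethyl in place of 1-(hydroxymethyl)ethyl gives a clearer difference, a 3.9-fold higher number from compound 2 to compound 4 (0.59 log units; beyond the scatter). Among the compounds shown here, with only two cores and one assay, this does not show that the change would behave alike on any other core.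

The compounds shown leave open what an amine in place of the carboxy would do. They also leave open how a longer chain on the amide-type nitrogen would compare.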